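Trifluoromethyl in place of bromo on the shared core

The compounds below may be only part of what the source reports. "The series", "measured", "known", "first", "only" and "open" are said of these compounds alone.

Of the compounds shown here, three have so far been measured in an assay for inhibition of Tryptophan 2,3-dioxygenase (Homo sapiens), with stated times of 10 min and 60 min; on this read-out higher numbers stand for weaker inhibition and lower numbers for stronger inhibition. Compound 1 `NCCn1ncc2c(NCc3ccccc3[N+](=O)[O-])cc(C(F)(F)F)cc21` reaches only the limit of the assay, giving > 100000 nM, which is a limit rather than a number (the limit of > 100000 nM in this assay, at which 1 of the 3 values shown sits). Compound 2 `O=[N+]([O-])c1cc(Cl)ccc1CNc1cc(C(F)(F)F)cc2[nH]ncc12` gives 1700 nM. Compound 3 `O=[N+]([O-])c1ccccc1CNc1cc(Br)cc2[nH]ncc12` gives 39000 nM, the higher of the two numbers; its nearest neighbour is compound 2, whose number sits lower by a margin beyond the usual scatter.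

Compound 4 `O=[N+]([O-])c1ccccc1CNc1cc(C(F)(F)F)cc2[nH]ncc12` has not yet been measured. It differs from compound 3 in one place: trifluoromethyl in place of bromo on an aromatic carbon. Among the compounds with values here, no measured pair isolates this exchange. Compound 2 carries the same trifluoromethyl group but also a chloro group elsewhere in the structure, so its number cannot be assigned to the trifluoromethyl alone.

Compound 4 is expected to give a lower number than compound 3, and the step of a 2.6-fold lower number from compound 3 to compound 4 (0.41 log units; beyond the scatter) is estimated to be modest in size, though probably beyond the scatter. The estimate for compound 4 in this assay is 15000 nM, with a range from 4000 nM to 50000 nM.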

Compound 4, half-maximal inhibitory concentration: 2550 nM
Estimate against measurement, compound 4: 5.9-fold (0.77 log units) above; measured number below the stated range.
By their numbers in this assay, from the lowest: compounds 2 and 4 (each within the scatter of the next); then compound 3. At a limit, above all of these: compound 1.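

In this assay, within the data shown here, the exchange of bromo for trifluoromethyl on an aromatic carbon now stands alone for the first time, and the step is large: a 15-fold lower number from compound 3 to compound 4 (1.18 log units; beyond the scatter). With hydrogen in place of chloro on an aromatic carbon the step stays within the scatter, a 1.5-fold higher number from compound 2 to compound 4 (0.18 log units; within the scatter), so the chloro group of compound 2 makes no difference that can be read here, and the low number of compound 2 no longer needs that group to be read. Compound 1, with 2-aminoethyl on an aromatic nitrogen, gives a limit and not a number, so the step with hydrogen on that nitrogen, an at least 39-fold lower number from compound 1 to compound 4 (1.59 log units; beyond the scatter), is large but has no fixed size: the limit of > 100000 nM in this assay, at which 1 of the 4 values shown sits.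

Only bromo and trifluoromethyl appear on this aromatic carbon among the compounds shown, so it remains open how a nitrile, a methyl group or a methoxy group there would read. On the aromatic nitrogen only hydrogen and 2-aminoethyl appear, which leaves a methyl group or a longer chain ending in a carboxylic acid open, and the nitro group is the same in all four compounds, which leaves an amine in its place open as well.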